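Four Aryl Triazoles Tested for Growth Inhibition in Breast Cancer Cells

A few compounds are considered here, and "the series" means these few. Any claim that something is new, unique, unknown or untested is made for them only; others in the source may bear on it.

The measured compounds:
Compound 1, `C=C1C[C@]23C[C@@]1(O)CC[C@H]2c1cc(Br)c(O)c(C)c1[C@@H]3Cn1cc(-c2ccc(OC)cc2)nn1`, gives in a functional assay on MCF7 cells (Homo sapiens) for cytotoxicity, read by MTT assay, with a stated time of 4 days (on this read-out higher numbers stand for weaker inhibition and lower numbers for stronger inhibition), the value > 20000 nM, which is a limit of the assay and not a number.
Compound 2, `C=C1C[C@]23C[C@@]1(O)CC[C@H]2c1cc(Br)c(O)c(C)c1[C@@H]3Cn1cc(-c2ccc(F)cc2)nn1`, gives in this assay the value 19200 nM.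
Compound 3, `C=C1C[C@]23C[C@@]1(O)CC[C@H]2c1cc(Br)c(O)c(C)c1[C@@H]3Cn1cc(-c2ccc(C)cc2)nn1`, gives in this assay the value > 20000 nM, again a limit of the assay.

Compound 3 therefore stands at the top edge of what this assay can report, and it shares that place with another compound: the limit of > 20000 nM in this assay, at which 2 of the 3 values shown sit. Two steps lead to compound 3. The first, a step that the two limits leave unreadable from compound 1 to compound 3, cannot be read, as both ends are limits. The second, an at least 1.0-fold higher number from compound 2 to compound 3 (0.01 log units; that floor lies within the scatter), lies within the scatter, and the remaining step, an at least 1.0-fold lower number from compound 1 to compound 2 (0.01 log units; that floor lies within the scatter), does as well. All three aryl variants thus sit at or just below the limit, and no change on the aromatic ring has moved the read-out in a readable way.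

Compound 4, `C=C1C[C@]23C[C@@]1(O)CC[C@H]2c1cc(Br)c(O)c(C)c1[C@@H]3Cn1cc(-c2ccc(Cl)cc2)nn1`, differs from compound 3 by chloro in place of methyl on an aromatic carbon. With the two steps that reach compound 3 either unreadable or within the scatter, the expected step is a step that the limit leaves unreadable from compound 3 to compound 4, that is, none beyond the scatter. Compound 4 is estimated at 22000 nM, with a range from 9000 nM to 60000 nM, most likely again reported only as a limit.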

Compound 4, half-maximal inhibitory concentration: 10200 nM
The estimate for compound 4 lay 2.2-fold (0.33 log units) above the measured number; the range from low to high includes it.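

Chloro on this aromatic carbon, para to a large group, gives the only pair of aryl variants here that can be compared as two real numbers, and that comparison is a 1.9-fold lower number from compound 2 to compound 4 (0.27 log units; within the scatter), so fluoro and chloro cannot be told apart in this assay. Set against methyl, the change gives an at least 1.9-fold lower number from compound 3 to compound 4 (0.29 log units; that floor lies within the scatter), and set against methoxy it gives an at least 1.9-fold lower number from compound 1 to compound 4 (0.29 log units; that floor lies within the scatter), so neither step shows a real change as it stands. Going by these compounds, both of these are only floors, and the true size of each stays unknown because the methyl and methoxy compounds give a limit and no number: the limit of > 20000 nM in this assay, at which 2 of the 4 values shown sit.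

Still open, on these data alone, is whether any group in this place can move the number beyond the scatter, as an amine, a carboxylic acid or a nitrile on the same ring might or might not do. Also open, as far as these compounds go, is whether the picture would hold if a longer chain stood in place of the 4-chlorophenyl group, or if the shared core itself were changed while chloro stayed where it is.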